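The source may hold more compounds than are shown below. What is called first, only, known or untested is meant among the compounds shown, and "the series" means these compounds.

Measured in a functional assay on A2780 cells (Homo sapiens) for inhibition, read by sulforhodamine B assay, with a stated time of 72 h; a higher number here means a weaker inhibitor, a lower number a stronger inhibitor:
Compound 1 `O=C(NCc1ccc(S(=O)(=O)c2ccccc2)cc1)c1cc2ccncc2s1`: 14 nM
Compound 2 `O=C(NCc1ccc(S(=O)(=O)c2ccccc2)cc1)c1c[nH]c2ccncc12`: 2100 nM

Within the data shown here, compound 1 holds the lower of the two numbers so far, and only compound 2 stands beside it for comparison. Compound 3 `O=C(NCc1ccc(S(=O)(=O)c2cccc(C(F)(F)F)c2)cc1)c1cc2ccncc2s1` keeps the core of compound 1 and changes one site trifluoromethyl in place of hydrogen on an aromatic carbon, on a six-membered aromatic ring of carbon only, meta to a large group. The same change reads as phenyl to 3-(trifluoromethyl)phenyl.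

Among the measured compounds shown here, only one measured step is available, a 150-fold higher number from compound 1 to compound 2 (2.18 log units; beyond the scatter), and it was large. That step exchanged the group on the carbonyl carbon and left the phenyl untouched, so it shows that the number in this assay can move far in this series but gives no size for the present change. For the measured compounds named here, no measured step covers a substituent on this ring. A small change is therefore expected, within the scatter, with a slight lean toward a higher number, and the uncertainty is wide. The expected step is a 1.4-fold higher number from compound 1 to compound 3 (0.15 log units; within the scatter). For compound 3 the estimated value is 20 nM, with an expected range from 6 nM to 70 nM.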

Compound 3, half-maximal inhibitory concentration: 1 nM
For compound 3 the middle estimate is 20-fold (1.30 log units) above the measured one, and the stated range ends above it.
By their numbers in this assay, from the lowest: compound 3; then compound 1; then compound 2.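

In this assay the phenyl of compound 1 turns out to be a responsive site: trifluoromethyl in place of hydrogen on an aromatic carbon gives a 14-fold lower number from compound 1 to compound 3 (1.15 log units; beyond the scatter) and so a stronger inhibitor, with the shared core kept. Among these compounds, the only earlier measured step, a 150-fold higher number from compound 1 to compound 2 (2.18 log units; beyond the scatter) on exchange of the group on the carbonyl carbon, showed only that a change at that other site can move the number far toward a weaker inhibitor, whereas this step shows that a single substituent on the six-membered aromatic ring of carbon only can move it far in the opposite direction. The compounds shown include no measurement that accounts for this step.

Going by these compounds, it remains open whether the step is specific to trifluoromethyl or would also appear with another substituent at the same place, such as a chlorine atom, a methoxy group, a nitrile or an amine, and whether moving trifluoromethyl elsewhere on this ring would keep a step of this size. On these data alone, it is equally open whether the same substituent would give a similar step when combined with the group on the carbonyl carbon of compound 2.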